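The source may hold more compounds than are shown below. What is called first, only, known or untested is meant among the compounds shown, and "the series" means these compounds.

Working notes on the dithiocarbamate series. In a functional assay on MDA-MB-435S cells (Homo sapiens) for antiproliferative activity, read by MTT assay, with a stated time of 72 h (a higher number here means a weaker inhibitor, a lower number a stronger inhibitor), compound 1 `COc1ccc2occ(CSC(=S)N(C(C)C)C(C)C)c(=O)c2c1` gives 1800 nM, the lower of the two numbers in hand; compound 2 `CCN(CC)C(=S)SCc1cc(=O)c2ccc(Cl)cc2o1` gives 23500 nM, a gap beyond the usual scatter, though compound 2 differs from compound 1 in more than one place and offers no single-change comparison. Compound 3 `COc1ccc2occ(CSC(=S)N3CCCC3)c(=O)c2c1` keeps the core of compound 1 and carries pyrrolidin-1-yl in place of diisopropylamino on a thiocarbonyl carbon. No comparable change has been measured in this series, so the direction is open; the step from compound 1 to compound 3 is expected to be small, within the scatter, as a 1.4-fold higher number from compound 1 to compound 3 (0.14 log units; within the scatter). Compound 3 is therefore estimated at 2500 nM in this assay, with a range of 900 nM to 7000 nM.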

Compound 3, half-maximal inhibitory concentration: 1800 nM
For compound 3 the middle estimate is 1.4-fold (0.14 log units) above the measured one, within the range that was stated.
By their numbers in this assay, from the lowest: compounds 1 and 3 (each within the scatter of the next); then compound 2.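

For the compounds shown here, this is the first single-change comparison: on a thiocarbonyl carbon, pyrrolidin-1-yl in place of diisopropylamino gives no change at the digits printed from compound 1 to compound 3 (within the scatter) in this assay. With the core of compound 1 held, this pair shows that the ring and the open-chain group can be exchanged here without a readable shift. Nothing in hand explains this result. Going by these compounds, it remains open whether piperidin-1-yl, morpholin-4-yl or dimethylamino at this place would read the same way.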